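Capping the pyrrolidine nitrogen: from compound 2 to compound 4

The source may hold more compounds than are shown below. What is called first, only, known or untested is meant among the compounds shown, and "the series" means these compounds.

Compound 1 `CNC(=O)CN1CC[C@H](n2c(Nc3ccccc3)nc3cnc(Nc4ccc(N5CCN(C)CC5)cc4)nc32)C1`: 170 nM
Compound 2 `CN1CCN(c2ccc(Nc3ncc4nc(Nc5ccc(F)cc5)n([C@@H]5CCCNC5)c4n3)cc2)CC1`: 120 nM
Compound 3 `CN1CCN(c2ccc(Nc3ncc4nc(Nc5ccccc5)n([C@H]5CCN(S(=O)(=O)C6CC6)C5)c4n3)cc2)CC1`: 1.6 nM

Of the compounds shown here, three sharing one core have been tested in a functional assay on HCC827 cells (Homo sapiens) for antiproliferative activity, read by MTT assay, with a stated time of 72 h; on this read-out lower numbers stand for stronger inhibition and higher numbers for weaker inhibition. Compound 2 stands second highest of the three numbers: in this assay compound 2 gives 120 nM, which lies within the scatter of compound 1 at 170 nM, while compound 3 at 1.6 nM sits far below both.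

Compound 4 `CN1CCN(c2ccc(Nc3ncc4nc(Nc5ccc(F)cc5)n([C@H]5CCN(C(=O)OC(C)(C)C)C5)c4n3)cc2)CC1` has not yet been measured. It differs from compound 2 in one place: 1-(tert-butoxycarbonyl)pyrrolidin-3-yl in place of piperidin-3-yl on an aromatic nitrogen.

Among the measured compounds shown here, one measured step bears on this change. a 110-fold lower number from compound 1 to compound 3 (2.03 log units; beyond the scatter) showed that the group carried on the ring nitrogen of the pyrrolidin-3-yl substituent can move the number by a very large amount, with cyclopropylsulfonyl giving a far lower number than (methylcarbamoyl)methyl. Compound 4 carries a tert-butoxycarbonyl on that nitrogen, a third kind of cap for which no direct comparison exists, and the pair of compound 2 and compound 4 also changes the ring itself, so the expectation is uncertain. The author expects a step downward beyond the scatter, estimated as a 6.0-fold lower number from compound 2 to compound 4 (0.78 log units; beyond the scatter), landing compound 4 at an estimated 20 nM with a range from 3 nM to 150 nM.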

Compound 4, half-maximal inhibitory concentration: 580 nM
For compound 4 the middle estimate is 29-fold (1.46 log units) below the measured one; measured number above the stated range.
By their numbers in this assay, from the lowest: compound 3; then compounds 2 and 1 (each within the scatter of the next); then compound 4.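

In this assay this change gave a 4.8-fold higher number from compound 2 to compound 4 (0.68 log units; beyond the scatter), so a cap on the ring nitrogen does not by itself go with a lower number at this position on the aromatic nitrogen. The earlier step, a 110-fold lower number from compound 1 to compound 3 (2.03 log units; beyond the scatter), had shown only how far the number can fall when one cap replaces another on the pyrrolidine nitrogen; compound 4 now shows that moving from an uncapped piperidin-3-yl to a 1-(tert-butoxycarbonyl)pyrrolidin-3-yl can raise the number beyond the scatter, so the substituent here can move the number in either direction. Nothing measured on these compounds accounts for the rise, and no supporting data point to a cause.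

The step changes ring size and cap together, so the compounds shown do not tell how much of it belongs to the five-membered ring and how much to the tert-butoxycarbonyl group. An uncapped pyrrolidin-3-yl, or a piperidin-3-yl carrying tert-butoxycarbonyl or cyclopropylsulfonyl on its nitrogen, with the same (4-fluorophenyl)amino group, would separate the two, and an acetyl or methanesulfonyl cap would show how the number follows the kind of cap.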